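A few compounds are considered here, and "the series" means these few. Any claim that something is new, unique, unknown or untested is made for them only; others in the source may bear on it.

In a functional assay on MCF7 cells (Homo sapiens) for cytotoxicity, with a stated time of 48 h (on this read-out higher numbers stand for weaker inhibition and lower numbers for stronger inhibition), compound 2, with the structure `O=[N+]([O-])c1ccc(CN2CCC(n3cc(CC(OCc4cc(-c5cccc(F)c5)no4)c4ccc(Br)cc4)nn3)CC2)cc1`, gives 8000 nM. Among the compounds with values here, the only other compound measured in this assay is compound 1, `O=[N+]([O-])c1ccc(CN2CCC(n3cc(CC(OCc4cc(-c5cccc(Br)c5)no4)c4ccc(Br)cc4)nn3)CC2)cc1`, which gives 6000 nM; the two differ in one place, and the step of a 1.3-fold higher number from compound 1 to compound 2 (0.12 log units; within the scatter) shows that this exchange at that position left the number within the scatter.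

Compound 3, `COc1cccc(-c2cc(COC(Cc3cn(C4CCN(Cc5ccc([N+](=O)[O-])cc5)CC4)nn3)c3ccc(Br)cc3)on2)c1`, has not been measured. It differs from compound 2 by methoxy in place of fluoro on an aromatic carbon. Within the data shown here, the one measured step that touches the same position, a 1.3-fold higher number from compound 1 to compound 2 (0.12 log units; within the scatter), swapped one halogen for another and produced no change beyond the scatter. Nothing measured here shows what a methoxy group does at this position, so the expectation rests on that single step and on the closeness of the two numbers already seen.

For this assay the step from compound 2 to compound 3 is therefore expected to be small, a 1.1-fold lower number from compound 2 to compound 3 (0.06 log units; within the scatter), with no direction that can be told from the data. Compound 3 is estimated to give 7000 nM, with a range from 3000 nM to 16000 nM.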

Compound 3, half-maximal inhibitory concentration: 7000 nM
Estimate against measurement, compound 3: no gap at the digits printed, within the range that was stated.
By their numbers in this assay, from the lowest: compounds 1, 3 and 2 (each within the scatter of the next).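

Up to this point, the place on the aromatic ring meta to a large group had seen only one halogen exchanged for another, whereas methoxy brings two heavy atoms in place of the single one of fluoro, and one hydrogen-bond acceptor where fluoro has none. Even so, in this assay the exchange of fluoro for methoxy gives a small step (a 1.1-fold lower number from compound 2 to compound 3 (0.06 log units; within the scatter)), and the exchange of bromo for methoxy gives another (a 1.2-fold higher number from compound 1 to compound 3 (0.07 log units; within the scatter)), so this assay does not separate these three groups at this place, although they are not all halogens. Nothing available explains why these three groups read alike.

On these data alone, whether this tolerance extends further remains open, since an amine, a carboxylic acid or a longer chain such as propoxy at the same place could still move the number beyond the scatter. The compounds shown also share everything else in the core, so they leave open whether changes elsewhere in the structure would matter more than changes at this one place.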